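Replacing a methoxymethoxy group in compound 3 with methoxy

The source may hold more compounds than are shown below. What is called first, only, known or untested is meant among the compounds shown, and "the series" means these compounds.

In a functional assay on A549 cells (Homo sapiens) for cytotoxicity, read by resazurin assay, with a stated time of 72 h (on this read-out higher numbers stand for weaker inhibition and lower numbers for stronger inhibition), compound 1 `COc1cc(OC)c(C(=O)/C=C/c2ccccc2)c(OC)c1` gives 4300 nM and compound 2 `COCOc1cc(OC)cc(OC)c1C(=O)/C=C/c1ccccc1` gives 3500 nM. Compound 3 `COCOc1cc(OCOC)c(C(=O)/C=C/c2ccccc2)c(OCOC)c1` gives 8400 nM, a number within the scatter of compound 1 but higher than that of compound 2 by more than the scatter. Compound 4 `COCOc1cc(OC)c(C(=O)/C=C/c2ccccc2)c(OCOC)c1` differs from compound 3 by hydrogen in place of methoxy on a saturated chain carbon bound to an oxygen on an aromatic ring. Within the data shown here, the only measured step bearing on this is the reverse change, a 1.2-fold lower number from compound 1 to compound 2 (0.09 log units; within the scatter). A small move toward a lower number is therefore expected in this assay, estimated as a 1.5-fold lower number from compound 3 to compound 4 (0.18 log units; within the scatter). Compound 4 is estimated at 5500 nM, with an expected range from 3000 nM to 10000 nM.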

Compound 4, half-maximal inhibitory concentration: 4200 nM
Estimate against measurement, compound 4: 1.3-fold (0.12 log units) above, within the range that was stated.
By their numbers in this assay, from the lowest: compounds 2, 4, 1 and 3 (each within the scatter of the next, the first and the last beyond it).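

In this assay, the change from methoxymethoxy to methoxy now gives a 2.0-fold lower number from compound 3 to compound 4 (0.30 log units; within the scatter), and the reverse change on another core gives a 1.2-fold higher number from compound 2 to compound 4 (0.08 log units; within the scatter). Each exchange of these two groups read so far therefore stays within the scatter. The size of the step also shows no measurable dependence on the core: the same change on two cores in this assay, a 1.2-fold lower number (0.09 log units; within the scatter) from compound 1 to compound 2 and a 2.0-fold higher number (0.30 log units; within the scatter) from compound 4 to compound 3, 2.5-fold (0.39 log units) apart, within the scatter of two such steps

The compounds shown cover only methoxy and methoxymethoxy at these places. As far as these compounds go, how a longer chain, an amine or a carboxylic acid on the saturated chain carbon would behave remains open.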